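Dropping the trifluoromethyl from a weak chloro analogue

The source may hold more compounds than are shown below. What is called first, only, known or untested is meant among the compounds shown, and "the series" means these compounds.

Compound 1 `O=C(O)CCc1ccc(OCc2nc(-c3cccc(C(F)(F)F)c3)no2)c(Cl)c1` is the weakest of the three measured compounds: in a functional assay on CHO cells for agonist activity at Free fatty acid receptor 1 (Homo sapiens), read by FLIPR and calcium flux, in the presence of a further agent that is not named here (a higher number here means that more compound is needed for the effect, a lower number that less compound is needed), compound 1 gives 30100 nM. For the measured compounds named here, its nearest neighbour in the numbers is compound 3 `O=C(O)CCc1ccc(OCc2nc(-c3cccc(C(F)(F)F)c3)no2)cc1`, which in this assay gives 1110 nM; the only single-point step available, a 27-fold lower number from compound 1 to compound 3 (1.43 log units; beyond the scatter), goes with hydrogen in place of chloro on an aromatic carbon. Furthest away lies compound 2 `CCc1ccc(-c2noc(COc3ccc(CCC(=O)O)cc3)n2)cc1`, which in this assay gives 210 nM; it differs from compound 1 in more than one place, so only the two values can be compared.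

Compound 4 `O=C(O)CCc1ccc(OCc2nc(-c3ccccc3)no2)c(Cl)c1` keeps the chloro of compound 1 and changes the other end: hydrogen in place of trifluoromethyl on an aromatic carbon. No measured pair shows a trifluoromethyl being removed, so the listed steps bear on this change only indirectly; the one measured step concerns the chloro and is large, but says nothing about this position. The expectation is therefore a modest step, a 1.5-fold higher number from compound 1 to compound 4 (0.17 log units; within the scatter), towards a higher number. Compound 4 is estimated at 45000 nM, within a range from 15000 nM to 140000 nM.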

Compound 4, half-maximal effective concentration: 13100 nM
Beside the measured number, compound 4's estimate is 3.4-fold (0.54 log units) above it; measured number outside the range, below it.
By their numbers in this assay, from the lowest: compound 2; then compound 3; then compound 4; then compound 1.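

In this assay, the trifluoromethyl on the aromatic ring of compound 1 is shown for the first time to be removable without any cost: replacing it with hydrogen gives a 2.3-fold lower number from compound 1 to compound 4 (0.36 log units; beyond the scatter), a modest step but a real one. So, on this chloro-bearing core, four heavy atoms can go from this place and less compound is needed for the effect, not more. The data offer no measured explanation for this shift.

The compounds shown leave open whether the same swap would go the same way on the core of compound 3, which carries hydrogen in place of the chloro. Also open, from the compounds shown here alone, is what a methoxy group or a nitrile at this place would do to the number.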